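A few compounds are considered here, and "the series" means these few. Any claim that something is new, unique, unknown or untested is made for them only; others in the source may bear on it.

Compound 1 `CN(CC(N)=O)Cc1ccc(OCc2cccc(Cl)c2)cc1` gives 70 mg/kg as measured
Compound 2 `C[C@@H](NCc1ccc(Cc2ccccc2)cc1)C(N)=O` gives 22.5 mg/kg as measured

In a functional assay on the whole organism with Mus musculus as the target, in the maximal electroshock model (a higher number here means that more compound is needed for the effect, a lower number that less compound is needed), compound 2 stands at 22.5 mg/kg and holds the lower of the two numbers. Less of it is needed than of compound 1, whose 70 mg/kg lies beyond the usual scatter of repeated measurements. These two compounds differ in more than one place, so their gap cannot be tied to any single structural change.

The next compound is compound 3 `C[C@@H](NCc1ccc(COc2ccccc2)cc1)C(N)=O` which has not yet been measured. Its difference from compound 2 is phenoxy in place of phenyl on a saturated chain carbon bound to an aromatic carbon with phenoxy in place of phenyl on a saturated chain carbon bound to an aromatic carbon. The rest of the structure stays the same. For the measured compounds named here, no measured pair shows what this swap does, so the best available guide is compound 2 at 22.5 mg/kg as the starting point. The expected change a 1.1-fold lower number from compound 2 to compound 3 (0.05 log units; within the scatter) is none beyond the scatter in this assay with no clear direction. For compound 3 the estimated value is 20 mg/kg with an expected range from 9 mg/kg to 45 mg/kg for the coming measurement.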

Compound 3, dose for half-maximal effect: 10.6 mg/kg
Compound 3: the middle estimate sits 1.9-fold (0.28 log units) above what was measured, and the stated range covers the measured number.
By their numbers in this assay, from the lowest: compound 3; then compound 2; then compound 1.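

In this assay, phenoxy in place of phenyl on a saturated chain carbon bound to an aromatic carbon gives a 2.1-fold lower number from compound 2 to compound 3 (0.33 log units; beyond the scatter), so this place accepts the swap and less compound is needed for the effect. For the compounds shown here, this is the first pair here that differs in one place only, which lets a change in the number be tied to a single structural change, something the gap from compound 1 to compound 2 could not do. Nothing measured on these compounds beyond this read-out bears on the result, so the reason for the gain remains unknown.

This single pair cannot separate the effect of the added oxygen from that of the extra atom in the chain, and a sulfur atom or an amine nitrogen in place of that oxygen, or a longer chain at the same carbon, would be needed to tell these apart. Going by these compounds, whether the same swap helps to the same extent on a different core, or with a chlorine on the outer ring of compound 3, also remains open.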